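The compounds below may be only part of what the source reports. "The series", "measured", "known", "first", "only" and "open" are said of these compounds alone.

Compound 2, `Nc1ccc(CNc2cc(Br)cc3[nH]ncc23)cc1`, carries an amino group on the six-membered aromatic ring of carbon only, and in an assay for inhibition of Indoleamine 2,3-dioxygenase 1 (Homo sapiens), with a stated time of 1 h, tested at 10 uM (on this read-out higher numbers stand for more inhibition at the one concentration tested (going by the name of the read-out) and lower numbers for less inhibition), compound 2 gives 3%, the lowest of the three numbers measured. Its nearest neighbour is compound 1, `OCc1ccc(CNc2cc(Br)cc3[nH]ncc23)cc1`, which carries a hydroxymethyl group in the same place and gives 45%. Compound 3, `ONc1cccc(CNc2cc(Br)cc3[nH]ncc23)c1`, gives 53%. Within the data shown here, the one measured step that touches compound 2 is a number 42 percentage points lower from compound 1 to compound 2 (beyond the scatter), so on this shared core the amino group goes with far less inhibition than the hydroxymethyl group.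

Compound 4, `NS(=O)(=O)c1ccc(CNc2cc(Br)cc3[nH]ncc23)cc1`, differs from compound 2 in one place: sulfamoyl in place of amino on an aromatic carbon. Among the measured compounds shown here, no measured step tells how sulfamoyl compares with amino on this core, so the expectation rests only on the fact that the two other groups measured here, in compound 1 and compound 3, sit well above compound 2. Leaving the amino group is therefore expected to raise the number, with the size of a number 32 percentage points higher from compound 2 to compound 4 (beyond the scatter) uncertain. For compound 4 an inhibition of about 35% is estimated, within a range from 5% to 65%.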

Compound 4, a percentage reported as inhibition, at one concentration (the size of the read-out at that concentration, not a potency): 20%
The estimate for compound 4 lay 15 percentage points above the measured number; low and high end bracket the measured number.
By their numbers in this assay, from the lowest: compound 2; then compound 4; then compounds 1 and 3 (each within the scatter of the next).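

In this assay, sulfamoyl in place of amino gives a number 17 percentage points higher from compound 2 to compound 4 (beyond the scatter), while sulfamoyl in place of hydroxymethyl gives a number 25 percentage points lower from compound 1 to compound 4 (beyond the scatter). At this position, para to a large group, the three groups therefore give three separate levels, with sulfamoyl in the middle, so amino is not simply a low outlier against every other group tried here. Nothing measured explains why the groups fall in this order.

As far as these compounds go, it remains open where a carboxylic acid, a methyl ester or a longer chain ending in a hydroxyl group would fall in this order. From the compounds shown here alone, it is also open whether sulfamoyl or amino would keep its level at another place on the ring, since compound 3 differs from these compounds in more than one place.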